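Aryl substituent swap on the shared core, compound 4 outlook

The source may hold more compounds than are shown below. What is called first, only, known or untested is meant among the compounds shown, and "the series" means these compounds.

Measured so far in a functional assay on SK-OV-3 cells (Homo sapiens) for cytotoxicity, read by MTT assay, with a stated time of 48 h; on this read-out lower numbers stand for stronger inhibition and higher numbers for weaker inhibition:
compound 1 `O=C(/C=C/c1ccc2c(c1)B(O)OC2)c1ccccc1`, 3400 nM
compound 2 `O=C(/C=C/c1ccc2c(c1)B(O)OC2)c1ccc(F)cc1`, 1400 nM
compound 3 `O=C(/C=C/c1ccc2c(c1)B(O)OC2)c1ccc([N+](=O)[O-])cc1`, 7900 nM

Compound 2 has the lowest number of the three: a 2.4-fold lower number from compound 1 to compound 2 (0.39 log units; beyond the scatter), and a 5.6-fold higher number from compound 2 to compound 3 (0.75 log units; beyond the scatter), with a 2.3-fold higher number from compound 1 to compound 3 (0.37 log units; beyond the scatter) placing compound 3 highest. Compound 4 `CCOC(=O)c1ccc(C(=O)/C=C/c2ccc3c(c2)B(O)OC3)cc1` differs from compound 2 in ethoxycarbonyl in place of fluoro on an aromatic carbon. Within the data shown here, the ethoxycarbonyl group has not yet been seen on this carbon, so the only bearing steps are the two leaving fluoro in favour of hydrogen or nitro, both of which raised the number modestly. A step back toward compound 1 or beyond is therefore anticipated in this assay. The expected step for compound 4 is a 2.9-fold higher number from compound 2 to compound 4 (0.46 log units; beyond the scatter). Compound 4 is estimated at 4000 nM, range 1500 nM to 11000 nM.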

Compound 4, half-maximal inhibitory concentration: 7100 nM
Beside the measured number, compound 4's estimate is 1.8-fold (0.25 log units) below it, within the range that was stated.
By their numbers in this assay, from the lowest: compound 2; then compound 1; then compounds 4 and 3 (each within the scatter of the next).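

In this assay, ethoxycarbonyl on this aromatic carbon, para to a large group, gives a 5.1-fold higher number from compound 2 to compound 4 (0.71 log units; beyond the scatter) and a 2.1-fold higher number from compound 1 to compound 4 (0.32 log units; beyond the scatter) so a second group now sits on the high side of hydrogen. With a 1.1-fold lower number from compound 3 to compound 4 (0.05 log units; within the scatter) ethoxycarbonyl and nitro cannot be told apart here, leaving compound 2 as the only one of the four with a number lower than that of compound 1. No measurement at hand accounts for these steps.

Open, from the compounds shown here alone, is whether chloro or methoxy would also give a number lower than that of compound 1. Also open, going by these compounds, is how a carboxylic acid, an amine or methoxycarbonyl would read on this carbon.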